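This account rests on a few compounds, and the source may have more. Where it says the series, first, only, none or still open, it means among the compounds named here.

Of the compounds shown here, three sharing one core have been measured. Compound 1 `Cc1ccc2c(c1)C1(C(=O)N2C)C(C#N)=C(N)Oc2cc3oc(-c4ccccc4)cc(=O)c3c(O)c21` gives 10200 nM in a functional assay on NCI-H1299 cells (Homo sapiens) for antiproliferative activity, read by MTT assay, with a stated time of 48 h; on this read-out higher numbers stand for weaker inhibition and lower numbers for stronger inhibition. Compound 2 `CN1C(=O)C2(C(C#N)=C(N)Oc3cc4oc(-c5ccccc5)cc(=O)c4c(O)c32)c2cc(Cl)ccc21` gives 11200 nM in this assay, and the step of a 1.1-fold higher number from compound 1 to compound 2 (0.04 log units; within the scatter) stays within the scatter. Compound 3 `Cc1ccc2c(c1)C1(C(=O)N2Cc2ccccc2)C(C#N)=C(N)Oc2cc3oc(-c4ccccc4)cc(=O)c3c(O)c21` shows only a limit of this assay, > 50000 nM. Compound 3 therefore sits at the limit of > 50000 nM in this assay, at which 1 of the 3 values shown sits. The step of an at least 4.9-fold higher number from compound 1 to compound 3 (0.69 log units; beyond the scatter) lies beyond the scatter.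

Compound 4 `N#CC1=C(N)Oc2cc3oc(-c4ccccc4)cc(=O)c3c(O)c2C12C(=O)N(Cc1ccccc1)c1ccc(Br)cc12` differs from compound 3 by bromo in place of methyl on an aromatic carbon. Among the compounds with values here, the one measured exchange of a halogen for methyl on an aromatic carbon, a 1.1-fold higher number from compound 1 to compound 2 (0.04 log units; within the scatter), made no difference beyond the scatter, while the benzyl group carried by compound 3 remains in compound 4. Compound 4 is thus expected to move by a step that the limit leaves unreadable from compound 3 to compound 4, with no step beyond the scatter. Compound 4 is estimated at 70000 nM, ranging from 30000 nM to 200000 nM.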

Compound 4, half-maximal inhibitory concentration: > 50000 nM
Compound 4: no number, only a limit; the forecaster's own chance of this, stated with the estimate: 75%; the middle value is on the limit's open side.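

Compound 3 and compound 4 both give only a limit in this assay, so no step between them can be read: the limit of > 50000 nM in this assay, at which 2 of the 4 values shown sit.

The compounds shown leave open whether bromo in place of methyl on an aromatic carbon changes anything when the benzyl group is present.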